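Methylpiperazine for Piperidine, Tried on a Second Core

The source may hold more compounds than are shown below. What is called first, only, known or untested is meant among the compounds shown, and "the series" means these compounds.

The three measured compounds and their values:

Compound 1, `O=C(NO)c1ccc(-c2nc(N3CCCCC3)c3ccccc3n2)cc1`, gives 66.4% in an assay on isolated protein for inhibition of protein deacetylase HDAC6 (Homo sapiens), tested at 0.5 uM; on this read-out lower numbers stand for less inhibition and higher numbers for more inhibition at the one concentration tested (going by the name of the read-out).
Compound 2, `CN1CCN(c2nc(-c3ccc(C(=O)NO)cc3)nc3ccccc23)CC1`, gives 89.4% in this assay.
Compound 3, `COc1cc(OC)c2c(N3CCCCC3)nc(-c3ccc(C(=O)NO)cc3)nc2c1`, gives 62.5% in this assay.

Compounds 1 and 2 differ in one place, (4-methylpiperazin-1-yl in place of piperidin-1-yl on an aromatic carbon), and that single exchange produced a number 23 percentage points higher from compound 1 to compound 2 (beyond the scatter). The core of compound 3 differs from the core of compound 1 in more than one place, so the difference between the two cores is not broken down here; what the numbers show is that compound 3 and compound 1 lie within the scatter of each other, while compound 2 stands above both, beyond the scatter.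

Compound 4, `COc1cc(OC)c2c(N3CCN(C)CC3)nc(-c3ccc(C(=O)NO)cc3)nc2c1`, has not yet been measured. It is related to compound 3 by 4-methylpiperazin-1-yl in place of piperidin-1-yl on an aromatic carbon, the same kind of change that carried compound 1 to compound 2; the surroundings are described alike except that the new group is meta to a 4-(hydroxycarbamoyl)phenyl group in compound 4, where in compound 2 it is meta to a large group. Because the earlier exchange gave a number 23 percentage points higher from compound 1 to compound 2 (beyond the scatter), a step of similar size is expected here, namely a number 19.5 percentage points higher from compound 3 to compound 4 (beyond the scatter) in this assay. On that basis compound 4 is estimated at 82%, with a likely range from 68% to 93%.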

Compound 4, a percentage reported as inhibition, at one concentration (the size of the read-out at that concentration, not a potency): 78.3%
Compound 4: middle estimate off by 3.7 percentage points, on the high side; the measured number falls inside the stated range.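

On the second core, the exchange of piperidin-1-yl for 4-methylpiperazin-1-yl again gave a higher number in this assay, with a number 15.8 percentage points higher from compound 3 to compound 4 (beyond the scatter). Among these compounds, the two steps can be read as the same in size: the same change on two cores in this assay, a number 23 percentage points higher (beyond the scatter) from compound 1 to compound 2 and a number 15.8 percentage points higher (beyond the scatter) from compound 3 to compound 4, 7.2 percentage points apart, within the scatter of two such steps This shows that the gain carried over between the core of compound 1 and the core of compound 3, but it rests on only two pairs at one concentration, so it does not show that the exchange would hold on any other core, nor does it explain why the number rises.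

The compounds shown leave open whether a piperazin-1-yl without the methyl, a morpholin-4-yl, or a longer chain ending in an amine would give a similar number at the same place. They also leave open whether the exchange would do the same on a core bearing other groups, such as a halogen, in place of those present in compound 3 and compound 4.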